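A few compounds are considered here, and "the series" means these few. Any claim that something is new, unique, unknown or untested is made for them only; others in the source may bear on it.

Three compounds share one core and differ only in the group attached to the benzylic ring. Compound 1 `CC(C)(C)c1ccc(CNCCCNS(=O)(=O)c2cc(C(F)(F)F)cc(C(F)(F)F)c2)cc1` gives 2300 nM in a functional assay on HPAC cells (Homo sapiens) for inhibition, read by MTT assay, with a stated time of 72 h; on this read-out higher numbers stand for weaker inhibition of growth and lower numbers for stronger inhibition of growth. Compound 2 `O=S(=O)(NCCCNCc1ccccc1Cl)c1cc(C(F)(F)F)cc(C(F)(F)F)c1` gives 10000 nM, and compound 3 `O=S(=O)(NCCCNCc1ccc(-c2ccccc2)cc1)c1cc(C(F)(F)F)cc(C(F)(F)F)c1` gives 2700 nM. On these three numbers compound 3 stands second highest, but its gap to compound 1 is within the scatter, while compound 2 sits beyond the scatter above it.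

Compound 4 `O=S(=O)(NCCCNCc1ccccc1)c1cc(C(F)(F)F)cc(C(F)(F)F)c1` has not yet been measured. Compared with compound 3 the change is hydrogen in place of phenyl on an aromatic carbon, so the added ring is removed and the benzylic ring carries nothing but hydrogens.

Among the compounds with values here, two measured steps bear on this. Trading tert-butyl for phenyl gave a 1.2-fold higher number from compound 1 to compound 3 (0.07 log units; within the scatter), so swapping one large group for another barely mattered. Replacing the whole 4-(tert-butyl)phenyl by 2-chlorophenyl gave a 4.3-fold higher number from compound 1 to compound 2 (0.64 log units; beyond the scatter), a clear weakening when the large group was lost and a small one placed elsewhere. Removing the phenyl altogether is therefore expected to weaken inhibition in this assay, probably by a step of similar size to that seen with compound 2, giving an expected 2.6-fold higher number from compound 3 to compound 4 (0.41 log units; beyond the scatter). Compound 4 is estimated at 7000 nM, with a likely range from 2500 nM to 20000 nM.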

Compound 4, concentration for 50% growth inhibition: 3200 nM
The estimate for compound 4 lay 2.2-fold (0.34 log units) above the measured number; low and high end bracket the measured number.
By their numbers in this assay, from the lowest: compounds 1, 3 and 4 (each within the scatter of the next); then compound 2.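

In this assay, this aromatic carbon tolerates losing its large group: with hydrogen in place of phenyl there is a 1.2-fold higher number from compound 3 to compound 4 (0.07 log units; within the scatter), and with hydrogen in place of tert-butyl there is a 1.4-fold higher number from compound 1 to compound 4 (0.14 log units; within the scatter), so neither large group can be told apart from hydrogen here. The opening comparison could not show this, as compound 2 had lost the large group and also carried a chloro; with hydrogen in place of that chloro there is a 3.1-fold lower number from compound 2 to compound 4 (0.49 log units; beyond the scatter), which ties the weaker inhibition of compound 2 to the 2-chlorophenyl ring and not to the missing large group. Nothing measured here explains why these changes have such different sizes.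

It remains open whether an amine or a carboxylic acid on this same aromatic carbon would also match hydrogen, or whether the tolerance holds only for the groups shown. Also open, from the compounds shown here alone, are whether a chloro placed on this carbon would weaken inhibition as it does in compound 2, and whether a longer chain in the shared core would change any of these steps.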